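The source may report more compounds than this note shows. Statements on the series, on what has been measured and on what is new or still open speak of the compounds shown alone.

Measured in a functional assay on SW-620 cells (Homo sapiens) for inhibition, read by sulforhodamine B assay, with a stated time of 48 h, tested at 0.1 uM; a higher number here means a weaker effect of the compound at the concentration tested, a lower number a stronger effect:
compound 1, `COc1cc(Cl)cc(-c2nn(-c3cccc(NC(=O)Nc4cccc(C(F)(F)F)c4)c3)cc2-c2ccncc2)c1`, 100%
compound 2, `COc1cc(Cl)cc(-c2nn(-c3cccc(NC(=O)Nc4ccc(Cl)c(C(F)(F)F)c4)c3)cc2-c2ccncc2)c1`, 96%
compound 3, `COc1cc(Cl)cc(-c2nn(-c3cccc(NC(=O)c4cccc(C(F)(F)F)c4)c3)cc2-c2ccncc2)c1`, 99%

Compound 2 gives the lowest of the three numbers, yet a number 4 percentage points lower from compound 1 to compound 2 (within the scatter) and a number 3 percentage points higher from compound 2 to compound 3 (within the scatter) are both within the scatter, as is a number 1 percentage points lower from compound 1 to compound 3 (within the scatter), so the three compounds are not told apart here. Compound 4, `O=C(Nc1cccc(-n2cc(-c3ccncc3)c(-c3cc(O)cc(Cl)c3)n2)c1)Nc1ccc(Cl)c(C(F)(F)F)c1`, differs from compound 2 by hydrogen in place of methyl on an oxygen on an aromatic ring. Going by the values given here, none of the measured steps touches this oxygen; all three concern the urea or amide part and all stayed within the scatter. No step beyond the scatter in this assay is therefore expected from compound 2 to compound 4, and the expected change is a number 1 percentage points lower from compound 2 to compound 4 (within the scatter). Compound 4 is estimated at 95% in this assay, with a range from 82% to 102%.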

Compound 4, a percentage reported as activity, at one concentration (the size of the read-out at that concentration, not a potency): 98%
For compound 4 the middle estimate is 3 percentage points below the measured one, within the range that was stated.
By their numbers in this assay, from the lowest: compounds 2, 4, 3 and 1 (each within the scatter of the next).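

Going by these compounds alone, the methoxy to hydroxy change on the 3-chloro-5-methoxyphenyl group gives the first step at this oxygen, and in this assay it reads a number 2 percentage points higher from compound 2 to compound 4 (within the scatter). Removing the methyl from this oxygen therefore does not separate the two compounds at this single concentration, and the step joins the urea and amide steps within the scatter. No evidence accompanying the result bears on it.

Going by these compounds, whether an ethoxy group or an amine at this place would separate from compound 2 stays open. On these data alone, whether compound 2 and compound 4 differ at other concentrations also stays open.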